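This account rests on a few compounds, and the source may have more. Where it says the series, first, only, none or still open, it means among the compounds named here.

Of the compounds shown here, three have been tested in an ADME assay on MT2 cells (Homo sapiens) for cytotoxicity; a lower number here means that less compound is tolerated, a higher number that more compound is tolerated. Compound 1 `CC(C)=CCOc1cc(Nc2ncnc(Cl)n2)ccc1C#N` gives only a limit of the assay, > 100000 nM, rather than a number. That reading is the limit of > 100000 nM in this assay, at which 1 of the 3 values shown sits. Compound 2 `COc1cc(OC)nc(Nc2ccc(Cl)c(OCC=C(C)C)c2)n1` gives 28000 nM in this assay. Compound 3 `CSc1ccnc(Nc2ccc(Cl)c(OCC=C(C)C)c2)n1` gives 2800 nM in this assay, which is the lowest of the two numbers recorded; compound 2 stands well above it, by a gap that lies beyond the usual scatter of repeated measurements, so compound 3 is the less tolerated of the two.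

The next compound, compound 4 `CCc1ccnc(Nc2ccc(Cl)c(OCC=C(C)C)c2)n1`, has not yet been measured in this assay. It differs from compound 3 in one place: ethyl in place of methylsulfanyl on an aromatic carbon. For the measured compounds named here, no pair of measured compounds in this set differs in that same way, so there is no measured step to lean on; the expectation rests on the change itself, in which one group of two heavy atoms gives way to another of two heavy atoms, with one hydrogen-bond acceptor lost. The account therefore expects only a small step, a 1.4-fold higher number from compound 3 to compound 4 (0.15 log units; within the scatter), probably no larger than the scatter and, if anything, toward more compound tolerated. Compound 4 is thus expected to give 4000 nM in this assay, within a range from 1500 nM to 12000 nM.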

Compound 4, half-maximal cytotoxic concentration: 330 nM
Compound 4: middle estimate off by 12-fold (1.08 log units), on the high side; measured number below the stated range.
By their numbers in this assay, from the lowest: compound 4; then compound 3; then compound 2. At a limit, above all of these: compound 1.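

In this assay, the place on an aromatic carbon next to the ring nitrogen proves sensitive to the group it carries: ethyl in place of methylsulfanyl gives an 8.5-fold lower number from compound 3 to compound 4 (0.93 log units; beyond the scatter) and so leaves less compound tolerated. For the compounds shown here, this is the first step between two compounds that differ in one place, and it shows that two groups with the same count of heavy atoms are not interchangeable at this position, even though the rest of the molecule stays the same. Nothing recorded for these compounds bears on why the number falls, so the step stands as an observation only.

A single pair cannot separate what ethyl brings from what the loss of methylsulfanyl takes away, nor show whether the same swap would give a step of similar size on the core of another compound. As far as these compounds go, how the number would move with a longer chain such as propyl at this position, or with an amine or a carboxylic acid there, remains open.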